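The source may report more compounds than this note shows. Statements on the series, on what has been measured and on what is new or still open speak of the compounds shown alone.

Working notes on the series, cytotoxicity arm.

Compound 1 `O=C1CSC(c2ccc(O)cc2)N1CCN1CCCCC1` has been run in an ADME assay on Vero cells (Chlorocebus sabaeus) for cytotoxicity, read by neutral red uptake, tested at 1575 ug/mL; a higher number here means a weaker effect of the compound at the concentration tested, a lower number a stronger effect; in that test compound 1 gives 12%. Within the data shown here, the only other compound with a number here is compound 2 `COc1ccccc1C1SCC(=O)N1CCN1CCCCC1`, which in this assay gives 17%. Of the two numbers, that of compound 1 is the smaller on paper, but the gap to compound 2 lies within the usual scatter, so the two cannot be told apart.

Compound 3 `O=C1CSC(c2ccc(F)cc2)N1CCN1CCCCC1` is the next member to be measured. It differs from compound 1 in one place: fluoro in place of hydroxy on an aromatic carbon. Among the measured compounds shown here, no pair of measured compounds in the set differs at a single place, so there is no measured step to size this change against.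

Expectation: the step from compound 1 to compound 3 in this assay is estimated at no change at the digits printed from compound 1 to compound 3 (within the scatter), that is, none beyond the scatter in either direction. Compound 3 is accordingly expected to give about 12%, with a range from 3% to 26%.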

Compound 3, a percentage reported as activity, at one concentration (the size of the read-out at that concentration, not a potency): 14%
For compound 3 the middle estimate is 2 percentage points below the measured one; measured number inside the range.
By their numbers in this assay, from the lowest: compounds 1, 3 and 2 (each within the scatter of the next).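

In this assay, fluoro in place of hydroxy on an aromatic carbon gives a number 2 percentage points higher from compound 1 to compound 3 (within the scatter), the first single-place step available in the series. At this position, para to a large group, hydroxy with its one hydrogen-bond donor and one hydrogen-bond acceptor and fluoro with none of either give read-outs that cannot be told apart at the single concentration tested. No supporting measurement bears on this result, so the step stands as an observation only.

On these data alone, whether this position would read the same with an amine, a carboxylic acid or a nitrile in place of hydroxy remains open. Also open, as far as these compounds go, is whether compound 1 and compound 3 would stay indistinguishable at lower concentrations, where a single high-concentration read-out gives no guidance.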